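Working notes: a polar amino chain replaces dimethylamino

The compounds below may be only part of what the source reports. "The series", "measured", "known", "first", "only" and "open" are said of these compounds alone.

Three compounds have numbers in a functional assay on CHO cells for antagonist activity at metabotropic glutamate receptor 1 (Rattus norvegicus), with a stated time of 5 min; on this read-out lower numbers stand for stronger inhibition and higher numbers for weaker inhibition. Compound 1 `CN(C)c1cc2c(NC3CCCCC3)ncnc2cn1` gives 199 nM and holds the lowest number of the three. Compound 2 `c1ccc2c(OC3CCCCC3)ncnc2c1` gives 694 nM, a gap to compound 1 that lies beyond the usual scatter. Compound 3 `OCCNc1cc2c(NCCO)ncnc2cn1` gives 6150 nM, the highest number of the set and far beyond the scatter from compound 1; compound 3 carries hydroxyethylamino groups at two places of the shared core, so no single change separates it from compound 1 or compound 2.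

Compound 4 `NCCCNc1cc2c(NC3CCCCC3)ncnc2cn1` is not yet measured. It differs from compound 1 in one place: (3-aminopropyl)amino in place of dimethylamino on an aromatic carbon. The cyclohexylamino group of compound 1 is kept. Going by the values given here, no measured pair isolates this change. The only polar amino chain in the measured set sits in compound 3, whose value 6150 nM is also shaped by its second substitution, so its weight as a guide is limited.

The expectation for compound 4 is a moderate rise in the number, that is, a step from compound 1 to compound 4 of a 2.5-fold higher number from compound 1 to compound 4 (0.40 log units; beyond the scatter) in this assay. Compound 4 is estimated at 500 nM, with a range from 100 nM to 3000 nM.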

Compound 4, inhibition constant: 200 nM
Beside the measured number, compound 4's estimate is 2.5-fold (0.40 log units) above it, and the stated range covers the measured number.
By their numbers in this assay, from the lowest: compounds 1 and 4 (each within the scatter of the next); then compound 2; then compound 3.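

In this assay, placing (3-aminopropyl)amino in place of dimethylamino on the aromatic carbon next to the ring nitrogen, with the cyclohexylamino group kept, gives a 1.0-fold higher number from compound 1 to compound 4 (0.00 log units; within the scatter). Going by these compounds alone, this is the first direct reading of a change at this position, and it shows that the position accepts a longer chain with more hydrogen-bond donors and acceptors without a step beyond the scatter, so the two compounds cannot be told apart on this read-out. No measurement in hand explains why these two groups read alike.

Still open, from the compounds shown here alone, is how far this acceptance extends: a carboxylic acid in place of the terminal amine, a longer chain such as (6-aminohexyl)amino, or a morpholine ring at the same carbon could each test it, and a plain hydrogen there would show whether the position needs a substituent at all. The compounds shown also leave open whether the same result would hold with a group other than cyclohexylamino at the second place on the shared core.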